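This account rests on a few compounds, and the source may have more. Where it says the series, first, only, none or still open, it means among the compounds named here.

Compound 1 `COc1cc(C)cc(-c2c(-c3ccnc(-c4ccc(C(C)=O)cc4)c3)cnn2CC#N)c1`, compound 2 `Cc1cc(O)cc(-c2nn(CC#N)cc2-c2ccnc(-c3ccc(Oc4ccccc4)cc3)c2)c1` and compound 3 `COc1cc(C)cc(-c2nn(CC#N)cc2-c2ccnc(-c3ccc(N(C)C)cc3)c2)c1` share one core and differ in their two outer aryl groups. In a functional assay on 786-0 cells (Homo sapiens) for inhibition, read by sulforhodamine B assay, with a stated time of 48 h (on this read-out higher numbers stand for lower toxicity in this test and lower numbers for higher toxicity in this test), compound 1 reaches only a limit of the assay, > 100000 nM. Compound 2 gives 18900 nM in this assay. Compound 3 also stands at a limit rather than a number, > 100000 nM, and so sits at the limit of > 100000 nM in this assay, at which 2 of the 3 values shown sit. Compound 4 `Cc1cc(O)cc(-c2nn(CC#N)cc2-c2ccnc(-c3ccc(N(C)C)cc3)c2)c1` has not yet been measured in this assay. It differs from compound 3 by hydrogen in place of methyl on an oxygen on an aromatic ring. Among the measured compounds shown here, no measured pair of compounds differs in one place alone, so the size of this step cannot be read from a measured step. For the measured compounds named here, compound 2, the one compound that carries the hydroxy group, is also the one compound that gives a number, while compound 1 and compound 3, both with the methoxy group, sit at the limit. The step from compound 3 to compound 4 is therefore expected to run toward higher toxicity, by about an at least 2.5-fold lower number from compound 3 to compound 4 (0.39 log units; beyond the scatter). Compound 4 is expected to give roughly 40000 nM, between 12000 nM and 100000 nM.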

Compound 4, concentration lethal to 50% of the cells: > 100000 nM
Compound 4 ended at the assay's limit; the forecaster's own chance of this, stated with the estimate: 40%; middle value at least 2.5-fold (0.39 log units) away from the limit.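

In this assay, the hydroxy group alone does not bring a readable value: with dimethylamino on the outer aryl group, the change from methoxy to hydroxy leaves the compound at the limit, and the step between compound 3 and compound 4 cannot be read. Dimethylamino in place of phenoxy on an aromatic carbon gives an at least 5.2-fold higher number from compound 2 to compound 4 (0.72 log units; beyond the scatter), so the one number in the set goes with the phenoxy group and not with the hydroxy group alone. Limits now dominate the set: the limit of > 100000 nM in this assay, at which 3 of the 4 values shown sit.

From the compounds shown here alone, whether methoxy to hydroxy shifts the value at all remains open, as reading it would take a methoxy partner of compound 2 that gives a number. Also open, going by these compounds, is whether a benzyloxy group or a carboxylic acid in place of phenoxy would give a number too.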